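Carbamate terminus changes on a shared core

The compounds below may be only part of what the source reports. "The series", "measured", "known", "first", "only" and "open" are said of these compounds alone.

Compound 1 `Cc1nc(S(C)(=O)=O)ccc1Oc1ncnc(OC2CCN(C(=O)O[C@H](C)CF)CC2)c1F` gives 196 nM in a functional assay on isolated protein for inhibition of Glucose-dependent insulinotropic receptor (Homo sapiens), read by HTRF and cAMP accumulation; a higher number here means that more compound is needed for the effect, a lower number that less compound is needed. Compound 2 `Cc1nc(S(C)(=O)=O)ccc1Oc1ncnc(OC2CCN(C(=O)O[C@H](C)C(F)(F)F)CC2)c1F` gives 9.2 nM in this assay, and compound 3 `Cc1nc(S(C)(=O)=O)ccc1Oc1ncnc(OC2CCN(C(=O)OC3(C(F)(F)F)CCC3)CC2)c1F` gives 14.3 nM. Compound 3 thus holds the second highest of the three numbers: its nearest neighbour is compound 2, with a 1.6-fold higher number from compound 2 to compound 3 (0.19 log units; within the scatter), and its furthest is compound 1, with a 14-fold lower number from compound 1 to compound 3 (1.14 log units; beyond the scatter). Compound 4 `Cc1nc(S(C)(=O)=O)ccc1Oc1ncnc(OC2CCN(C(=O)SC3CCC3)CC2)c1F` carries a group of 5 heavy atoms (4 carbon, 1 sulfur; one four-membered non-aromatic ring of carbon only) in place of a group of 9 heavy atoms (5 carbon, 1 oxygen, 3 fluorine; one four-membered non-aromatic ring of carbon only), on a carbonyl carbon. Among the compounds with values here, no measured step covers a sulfur for oxygen exchange at this carbonyl; the steps that bear on it are a 21-fold lower number from compound 1 to compound 2 (1.33 log units; beyond the scatter) and a 14-fold lower number from compound 1 to compound 3 (1.14 log units; beyond the scatter), both large and both tied to the three fluorines that compound 4 lacks. A clearly higher number is therefore expected for compound 4, a 6.3-fold higher number from compound 3 to compound 4 (0.80 log units; beyond the scatter), because a 14-fold lower number from compound 1 to compound 3 (1.14 log units; beyond the scatter) was large. Compound 4 is estimated at 90 nM, with a range of 20 nM to 400 nM.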

Compound 4, half-maximal effective concentration: 8.51 nM
The estimate for compound 4 lay 11-fold (1.02 log units) above the measured number, outside the stated range (below it).
By their numbers in this assay, from the lowest: compounds 4, 2 and 3 (each within the scatter of the next); then compound 1.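

With a 1.7-fold lower number from compound 3 to compound 4 (0.23 log units; within the scatter) and a 1.1-fold lower number from compound 2 to compound 4 (0.03 log units; within the scatter) the cyclobutylsulfanyl group on the carbonyl carbon stands level with both trifluoromethyl-bearing groups. Trifluoromethyl is thus not required at this place for a low number, while a 23-fold lower number from compound 1 to compound 4 (1.36 log units; beyond the scatter) leaves the fluoromethyl-bearing compound apart from this group too. Nothing available explains how a group without fluorine matches these two.

Still open, as far as these compounds go, is whether cyclobutoxy on the carbonyl carbon would read like cyclobutylsulfanyl, which would separate the sulfur from the ring. From the compounds shown here alone, how a longer chain on the sulfur would read is also open.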